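Chloro on the Phenyl Group of Compound 1

This account rests on a few compounds, and the source may have more. Where it says the series, first, only, none or still open, it means among the compounds named here.

Compound 1 `C=C1C[C@]23C[C@@]1(O)CC[C@H]2c1ccc(O)c(C)c1[C@@H]3Cn1cc(-c2ccccc2)nn1` has been tested in a functional assay on SMMC-7721 cells (Homo sapiens) for cytotoxicity, read by MTT assay, with a stated time of 4 days; on this read-out higher numbers stand for weaker inhibition and lower numbers for stronger inhibition. In this assay compound 1 reaches only the limit of > 20000 nM, so no number is known for it. Compound 2 `C=C1C[C@]23C[C@@]1(O)CC[C@H]2c1cc(Br)c(O)c(C)c1[C@@H]3Cn1cc(-c2ccccc2)nn1`, carrying bromo in place of hydrogen on an aromatic carbon, likewise shows only the limit of > 20000 nM. The step that the two limits leave unreadable from compound 1 to compound 2 cannot be read, since (the limit of > 20000 nM in this assay, at which 2 of the 2 values shown sit). Compound 3 `C=C1C[C@]23C[C@@]1(O)CC[C@H]2c1ccc(O)c(C)c1[C@@H]3Cn1cc(-c2ccc(Cl)cc2)nn1` differs from compound 1 by chloro in place of hydrogen on an aromatic carbon. Going by the values given here, no measured step gives a size for this change. Compound 3 is expected to remain at the limit too, with an estimate of 30000 nM between 8000 nM and 100000 nM, a step that the limit leaves unreadable from compound 1 to compound 3.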

Compound 3, half-maximal inhibitory concentration: > 20000 nM
Compound 3: only a limit was reported; the forecaster's own chance of this, stated with the estimate: 80%; the middle value lies beyond the limit too.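

Going by these compounds alone, compound 3, like compound 1, reaches only a limit and not a number, so no step between them can be read: the limit of > 20000 nM in this assay, at which 3 of the 3 values shown sit. The compounds shown leave open what change to the shared core would give a readable number in this assay.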